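A few compounds are considered here, and "the series" means these few. Any claim that something is new, unique, unknown or untested is made for them only; others in the source may bear on it.

Measured in an ADME assay (liver) for metabolic stability, with Liver microsome (Homo sapiens) as the target, read by LC-MS, using microsomes, with a stated time of 1 h, tested at 5 uM; a higher number here means that more of the compound is left, a lower number that less of the compound is left:

- compound 1 `Cc1nc(-c2ccccc2)c(C(=O)N2CCN(c3cccc(Cl)c3)CC2)o1` gives 13.5%
- compound 2 `COc1cc(OC)cc(N2CCN(C(=O)c3oc(C)nc3-c3ccccc3F)CC2)c1` gives 15%
- compound 3 `COc1cc(-c2nc(C)oc2C(=O)N2CCN(c3cccc(Cl)c3)CC2)ccc1O` gives 70.3%

Compound 1 has the lowest of the three numbers, although its value lies within the usual scatter of the value for compound 2. Among the compounds with values here, compound 3 stands well apart, with a number 56.8 percentage points higher from compound 1 to compound 3 (beyond the scatter) as the only measured step between compounds that differ in one place. That step, 4-hydroxy-3-methoxyphenyl in place of phenyl, lies elsewhere in the molecule and leaves the chloro group untouched, so it says little here.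

Compound 4 `Cc1nc(-c2ccccc2)c(C(=O)N2CCN(c3cccc(C#N)c3)CC2)o1` keeps the core of compound 1 and changes one group: cyano in place of chloro on an aromatic carbon. Here 3-chlorophenyl becomes 3-cyanophenyl. Compound 2 also lacks the chloro group but differs in other places too, and it gives 15% in this assay. No measurement isolates this change, so only a modest step is expected, with a wide margin. The expected change is a number 6.5 percentage points higher from compound 1 to compound 4 (within the scatter) and would not clearly exceed the scatter. The estimated value for compound 4 is 20%, within an expected range from 7% to 45%.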

Compound 4, percent of the compound remaining: 8%
The estimate for compound 4 lay 12 percentage points above the measured number, within the range that was stated.
By their numbers in this assay, from the lowest: compounds 4, 1 and 2 (each within the scatter of the next); then compound 3.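

In this assay, within the data shown here, cyano in place of chloro gives a number 5.5 percentage points lower from compound 1 to compound 4 (within the scatter), the first measured step at this position of the shared core. Among these compounds, exchanging 3-chlorophenyl for 3-cyanophenyl therefore leaves the number indistinguishable from that of compound 1, so this one swap does not separate the two groups, and the only step beyond the scatter so far remains the change made elsewhere in compound 3. No measurement available here explains why these two groups read alike. From the compounds shown here alone, only chloro and cyano have been compared at this position, so it remains open whether an amine or a carboxylic acid there would shift the number. Going by these compounds, it is also open whether the 4-hydroxy-3-methoxyphenyl group of compound 3 would keep its high number with cyano in place of chloro.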